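The source may hold more compounds than are shown below. What is called first, only, known or untested is meant among the compounds shown, and "the series" means these compounds.

In a functional assay on CAL-51 cells (Homo sapiens) for antiproliferative activity, read by luminescence and CellTiter-Glo, with a stated time of 3 days (a higher number here means a weaker inhibitor, a lower number a stronger inhibitor), three compounds that share one core and differ only in the ring on an oxygen on an aromatic ring have been measured. Compound 1 `COc1cc(C(=O)N(C)C)ccc1Nc1nc(OC2CCCCC2)c2cc[nH]c2n1`, carrying cyclohexyl, gives 190 nM. Compound 2 `COc1cc(C(=O)N(C)C)ccc1Nc1nc(OC2CCCC2)c2cc[nH]c2n1`, carrying cyclopentyl, gives 497 nM. Compound 3 `COc1cc(C(=O)N(C)C)ccc1Nc1nc(OC2CCOCC2)c2cc[nH]c2n1`, carrying oxan-4-yl, gives 198 nM. Compound 3 thus sits in the lower-numbered pair with the cyclohexyl compound, as shown by a 1.0-fold higher number from compound 1 to compound 3 (0.02 log units; within the scatter), and it stands clear of the cyclopentyl compound, as shown by a 2.5-fold lower number from compound 2 to compound 3 (0.40 log units; beyond the scatter).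

The next structure, compound 4 `COc1cc(C(=O)N(C)C)ccc1Nc1nc(OC2COC2)c2cc[nH]c2n1`, has oxetan-3-yl in place of oxan-4-yl on an oxygen on an aromatic ring. Among the measured compounds shown here, two measured steps bear on this change. Exchanging cyclohexyl for oxan-4-yl gave a 1.0-fold higher number from compound 1 to compound 3 (0.02 log units; within the scatter), so the ring oxygen alone offers no reason to expect a shift. Going to the smaller carbocycle gave a 2.6-fold higher number from compound 1 to compound 2 (0.42 log units; beyond the scatter), a modest rise. No four-membered ring has been measured here, so the extrapolation is uncertain. A modest rise in this assay is therefore expected, similar to or slightly larger than that cyclopentyl step. The expected step is a 3.0-fold higher number from compound 3 to compound 4 (0.48 log units; beyond the scatter). For compound 4 the estimated value is 600 nM, with an expected range of 250 nM to 1500 nM.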

Compound 4, half-maximal inhibitory concentration: 1960 nM
The estimate for compound 4 lay 3.3-fold (0.51 log units) below the measured number; the measured number lies above the stated range.
By their numbers in this assay, from the lowest: compounds 1 and 3 (each within the scatter of the next); then compound 2; then compound 4.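

In this assay, among the compounds shown here, the ring on an oxygen on an aromatic ring proves far less forgiving than the earlier compounds suggested: cyclohexyl and oxan-4-yl had stayed within the scatter of each other and cyclopentyl had cost only a modest step, whereas oxetan-3-yl gives the largest steps in the set (a 9.9-fold higher number from compound 3 to compound 4 (1.00 log units; beyond the scatter)), (a 10-fold higher number from compound 1 to compound 4 (1.01 log units; beyond the scatter)). The loss goes beyond the cyclopentyl compound as well (a 3.9-fold higher number from compound 2 to compound 4 (0.60 log units; beyond the scatter)), so among these four compounds the number climbs as the ring shrinks from the six-membered pair through cyclopentyl to the four-membered oxetan-3-yl, and the ring oxygen that changed nothing at six-membered size does not rescue the smallest ring. Nothing available explains this rise.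

The compounds shown cannot separate the effect of the four-membered ring itself from that of its oxygen, a question that cyclobutyl on the same oxygen would address directly. They also leave open how this position responds to a ring holding an amine, such as piperidin-4-yl, or to an open chain such as isopropyl.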